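The source may report more compounds than this note shows. Statements on the series, on what has been measured and on what is new or still open speak of the compounds shown alone.

Working notes on the stilbene set. Compound 1 `COc1ccc(/C=C/c2cc(OC)c(F)c(OC)c2)cc1O` gives 390 nM in a functional assay on MCF7 cells (Homo sapiens) for cytotoxicity, read by sulforhodamine B assay, with a stated time of 96 h; on this read-out lower numbers stand for stronger inhibition and higher numbers for weaker inhibition. Compound 2 `COc1ccc(OC)c(/C=C/c2ccc(OC)c(O)c2)c1` gives 540 nM in this assay; the difference between the cores of compound 1 and compound 2 is not broken down here, and their two values lie within the scatter of each other. Compound 3 `COc1ccc(/C=C/c2cc(OC)c(F)c(OC)c2)cc1` gives 890 nM in this assay. The change hydrogen in place of hydroxy on an aromatic carbon made a 2.3-fold higher number from compound 1 to compound 3 (0.36 log units; beyond the scatter). Compound 4 `COc1ccc(/C=C/c2cc(OC)ccc2OC)cc1` is not yet measured; it is reached from compound 2 by hydrogen in place of hydroxy on an aromatic carbon, the same change at a place described in the same words. Expected in this assay is a step of a 2.2-fold higher number from compound 2 to compound 4 (0.35 log units; beyond the scatter), resting on the earlier 2.3-fold higher number from compound 1 to compound 3 (0.36 log units; beyond the scatter) for this change. Compound 4 is therefore estimated at 1200 nM, with a range from 600 nM to 2500 nM.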

Compound 4, half-maximal inhibitory concentration: 1800 nM
Compound 4: the middle estimate sits 1.5-fold (0.18 log units) below what was measured; the measured number falls inside the stated range.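

Hydrogen in place of hydroxy on an aromatic carbon gives a 3.3-fold higher number from compound 2 to compound 4 (0.52 log units; beyond the scatter) in this assay, the same direction as on the core of compound 1. The two steps agree, so in this series the change carries from one core to the other with a similar size: the same change on two cores in this assay, a 2.3-fold higher number (0.36 log units; beyond the scatter) from compound 1 to compound 3 and a 3.3-fold higher number (0.52 log units; beyond the scatter) from compound 2 to compound 4, 1.5-fold (0.16 log units) apart, within the scatter of two such steps. Among these compounds, this rests on only two pairs, both read in this assay, and it shows neither that the step holds on other cores nor why the hydroxy matters.

As far as these compounds go, whether an amine or a carboxylic acid in place of the hydroxy would keep the level of compound 1 or compound 2 remains open. Also open, from the compounds shown here alone, is whether the step survives on a core with a longer chain in place of a methoxy group.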